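Swapping a methoxy for fluoro on a pyrazoline series

The compounds below may be only part of what the source reports. "The series", "measured", "known", "first", "only" and "open" are said of these compounds alone.

Of the compounds shown here, three sharing one core have been tested in a functional assay on WM 266-4 cells (Homo sapiens) for antiproliferative activity, read by MTT assay, with a stated time of 48 h; a lower number here means a stronger inhibitor, a higher number a weaker inhibitor. Compound 1 `COc1ccc(C2=NN(c3nc(-c4ccc(Br)cc4)cs3)C(c3cccs3)C2)cc1` gives 5870 nM, the lowest of the three numbers. Compound 3 `COc1ccc(C2=NN(c3nc(-c4ccc(C(F)(F)F)cc4)cs3)C(c3cccs3)C2)cc1` gives 8110 nM, and the step of a 1.4-fold higher number from compound 1 to compound 3 (0.14 log units; within the scatter) stays within the scatter, so these two cannot be ranked. Compound 2 `COc1ccc(C2=NN(c3nc(-c4ccc(OC)cc4)cs3)C(c3cccs3)C2)cc1` gives 31600 nM, and the step of a 5.4-fold higher number from compound 1 to compound 2 (0.73 log units; beyond the scatter) is a modest but real weakening; likewise a 3.9-fold lower number from compound 2 to compound 3 (0.59 log units; beyond the scatter).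

Compound 4 `Fc1ccc(C2=NN(c3nc(-c4ccc(Br)cc4)cs3)C(c3cccs3)C2)cc1` has not been measured. It differs from compound 1 by fluoro in place of methoxy on an aromatic carbon. The measured steps all concern a different part of the molecule, where methoxy was exchanged for bromo or trifluoromethyl, and both exchanges gave modestly lower numbers than the methoxy compound. Within the data shown here, they bear on the present change only loosely, since here methoxy is removed at another site, and no measured pair shows what that does. The most that can be said is that removing methoxy did no harm elsewhere, while nothing shows a gain.

Compound 4 is therefore expected to sit close to compound 1, with an estimated step of a 1.2-fold lower number from compound 1 to compound 4 (0.07 log units; within the scatter). The estimated value for compound 4 in this assay is 5000 nM, with a range from 1500 nM to 16000 nM.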

Compound 4, half-maximal inhibitory concentration: 220 nM
Compound 4: the middle estimate sits 23-fold (1.36 log units) above what was measured; the whole stated range lies above it.
By their numbers in this assay, from the lowest: compound 4; then compounds 1 and 3 (each within the scatter of the next); then compound 2.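

Until now, every measured change sat on the other aryl group, where bromo, methoxy and trifluoromethyl were exchanged, so this position was untested. In this assay, the change from 4-methoxyphenyl to 4-fluorophenyl gives a 27-fold lower number from compound 1 to compound 4 (1.43 log units; beyond the scatter), a large step that shows this position strongly affects the result and that the methoxy group is not needed here for activity in these cells. This step also exceeds the biggest step seen at the other site, a 5.4-fold higher number from compound 1 to compound 2 (0.73 log units; beyond the scatter), but no measured information explains why the new change has such an effect.

As far as these compounds go, it remains open whether the gain comes from fluoro itself or simply from losing methoxy, a question that a hydrogen, a chloro, an amine or a carboxylic acid at the same position could help to answer. It is also unknown whether the gain would carry over to the other partner groups, since the 4-fluorophenyl group appears here only alongside bromo and not with the trifluoromethyl of compound 3 or the methoxy of compound 2.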